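Lengthening the amine chain one carbon further

This account rests on a few compounds, and the source may have more. Where it says the series, first, only, none or still open, it means among the compounds named here.

Compound 1 `CO[C@@]12CCN(C)C[C@H]1[C@H](c1ccccc1)C(C#N)=C(N)O2` gives 19800 nM in a functional assay on trachea (Cavia porcellus); on this read-out higher numbers stand for weaker inhibition and lower numbers for stronger inhibition.
Compound 2 `CO[C@@]12CCN(C)C[C@H]1[C@H](c1ccc3ccccc3c1)C(C#N)=C(N)O2` gives 24200 nM in this assay.
Compound 3 `CCN1CC[C@@]2(OC)OC(N)=C(C#N)[C@@H](c3ccc4ccccc4c3)[C@@H]2C1` gives 28300 nM in this assay.

Compound 3 stands at the highest of the three numbers, but its separation from compound 2 and from compound 1 lies within the scatter, so the three measured compounds cannot be told apart on this read-out. Compound 4 `CCCN1CC[C@@]2(OC)OC(N)=C(C#N)[C@@H](c3ccc4ccccc4c3)[C@@H]2C1` differs from compound 3 in one place: methyl in place of hydrogen on a saturated chain carbon, two bonds along the chain from an amine nitrogen in a ring. Going by the values given here, the one measured step that bears on this change is the preceding extension along the same chain, a 1.2-fold higher number from compound 2 to compound 3 (0.07 log units; within the scatter), which is methyl to ethyl on the amine nitrogen and stayed within the scatter. The present change, ethyl to propyl, is the same difference cut one bond further out. Among the compounds with values here, with only that single step as a guide, no shift beyond the scatter is expected from compound 3 to compound 4. Compound 4 is therefore estimated at 30000 nM in this assay, with a range from 12000 nM to 75000 nM. That estimate corresponds to an expected 1.1-fold higher number from compound 3 to compound 4 (0.03 log units; within the scatter).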

Compound 4, half-maximal inhibitory concentration: 37100 nM
Estimate against measurement, compound 4: 1.2-fold (0.09 log units) below; the measured number falls inside the stated range.
By their numbers in this assay, from the lowest: compounds 1, 2, 3 and 4 (each within the scatter of the next).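

With propyl, the chain on this amine nitrogen has now been extended one carbon beyond ethyl, and in this assay methyl in place of hydrogen on a saturated chain carbon, two bonds along the chain from an amine nitrogen in a ring, gives a 1.3-fold higher number from compound 3 to compound 4 (0.12 log units; within the scatter). Taken together, the extension also gives a two-carbon comparison that the earlier compounds could not offer: propyl in place of methyl on this amine nitrogen gives a 1.5-fold higher number from compound 2 to compound 4 (0.19 log units; within the scatter), so across the methyl, ethyl and propyl chains of compound 2, compound 3 and compound 4 this read-out does not separate any pair. No measurement shown here offers an explanation for this result.

The compounds shown leave open whether a longer chain such as butyl, or a benzyl group, at this amine nitrogen would move the number beyond the scatter. They also leave open whether an ethyl or propyl chain would behave the same way on the core of compound 1.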